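This account rests on a few compounds, and the source may have more. Where it says the series, first, only, none or still open, it means among the compounds named here.

In a functional assay on HeLa cells (Homo sapiens) for antiproliferative activity, read by sulforhodamine B assay, with a stated time of 48 h (on this read-out lower numbers stand for stronger inhibition and higher numbers for weaker inhibition), compound 3 (`COc1ccc(C(=O)/C=C\Nc2ccc(-c3nc4cc(OC)c(OC)c(OC)c4s3)cc2)cc1[N+](=O)[O-]`) gives 11400 nM. Two close relatives give similar results: compound 2 (`COc1ccc(C(=O)/C=C\Nc2ccc(-c3nc4cc(OC)c(OC)c(OC)c4s3)cc2C)cc1[N+](=O)[O-]`) gives 13400 nM, and compound 1 (`COc1cc(C(=O)/C=C\Nc2ccc(-c3nc4cc(OC)c(OC)c(OC)c4s3)cc2C)cc([N+](=O)[O-])c1OC`) gives 13100 nM. All three values lie within the usual scatter of one another, so compound 3 holds no real rank among them.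

The next compound, compound 4 (`COc1cc(C(=O)/C=C\Nc2ccc(-c3nc4cc(OC)c(OC)c(OC)c4s3)cc2)cc([N+](=O)[O-])c1OC`), differs from compound 3 at a single place, with methoxy in place of hydrogen on an aromatic carbon. The closest evidence is the same swap run in reverse on the methyl-carrying pair, where hydrogen replaces methoxy: a 1.0-fold higher number from compound 1 to compound 2 (0.01 log units; within the scatter). Going by the values given here, the only other measured change, hydrogen in place of methyl, gives a 1.2-fold lower number from compound 2 to compound 3 (0.07 log units; within the scatter). Compound 4 lacks that methyl but keeps the extra methoxy of compound 1, so it combines two changes that have each stayed within the scatter. Three compounds are a thin base, but they give no sign that the added methoxy should matter here. No step beyond the scatter is expected in this assay, and the estimated step is a 1.0-fold higher number from compound 3 to compound 4 (0.00 log units; within the scatter). For compound 4 the estimated value is 11500 nM, with an expected range from 6500 nM to 20000 nM.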

Compound 4, half-maximal inhibitory concentration: 7800 nM
Estimate against measurement, compound 4: 1.5-fold (0.17 log units) above; low and high end bracket the measured number.
By their numbers in this assay, from the lowest: compounds 4, 3, 1 and 2 (each within the scatter of the next).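

In this assay, methoxy in place of hydrogen, on an aromatic carbon ortho to a methoxy group and meta to a nitro group, can now be read on the core without the methyl as well as on the core with it. There it gives a 1.5-fold lower number from compound 3 to compound 4 (0.16 log units; within the scatter), and the two readings of this swap can be set side by side: the same change on two cores in this assay, a 1.0-fold higher number (0.01 log units; within the scatter) from compound 1 to compound 2 and a 1.5-fold higher number (0.16 log units; within the scatter) from compound 4 to compound 3, 1.4-fold (0.15 log units) apart, within the scatter of two such steps

Hydrogen in place of methyl also gains a second reading, a 1.7-fold lower number from compound 1 to compound 4 (0.23 log units; within the scatter), which can likewise be compared with the first: the same change on two cores in this assay, a 1.2-fold lower number (0.07 log units; within the scatter) from compound 2 to compound 3 and a 1.7-fold lower number (0.23 log units; within the scatter) from compound 1 to compound 4, 1.4-fold (0.15 log units) apart, within the scatter of two such steps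

Each swap therefore stays within the scatter on both cores, so the flat result seen earlier is not confined to a single pair of compounds.

Every compound shown carries only hydrogen or methoxy at this position, so it remains open how an amine, a carboxylic acid or a longer chain such as butoxy would behave there. With only these two small swaps on hand, and no step beyond the scatter among them, it is also unknown whether any change at this position can move the number by a clear margin.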